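This account rests on a few compounds, and the source may have more. Where it says the series, first, only, none or still open, it means among the compounds named here.

Series notes, step from compound 2 to compound 3.

Compound 1 `COc1cc(-c2cc(/C=C/C(=O)c3ccc(N)cc3)[nH]n2)cc(OC)c1OC` gives -24% in a functional assay on MCF7 cells (Homo sapiens) for cytotoxicity, read by sulforhodamine B assay, with a stated time of 48 h, tested at 10 uM; a lower number here means a stronger effect, a higher number a weaker effect of the compound at the concentration tested. For the measured compounds named here, compound 2 `COc1ccc(C(=O)/C=C/c2cc(-c3cc(OC)c(OC)c(OC)c3)n[nH]2)cc1` gives -64%, the lowest of the two numbers measured; the one measured step, a number 40 percentage points lower from compound 1 to compound 2 (beyond the scatter), shows that a change on the aryl ketone end of the shared core can move the read-out by a large margin.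

Compound 3 `COc1cc(-c2cc(/C=C/C(=O)c3ccc(F)c(F)c3)[nH]n2)cc(OC)c1OC` carries 3,4-difluorophenyl in place of 4-methoxyphenyl on a carbonyl carbon. Going by the values given here, no measured step covers a fluorine-for-methoxy exchange, so only the size of the earlier step at this position guides the expectation. For compound 3 a step of a number 19 percentage points higher from compound 2 to compound 3 (beyond the scatter) toward a weaker effect is expected, with wide uncertainty. The expected value for compound 3 is -45%, within -80% to -10%.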

Compound 3, a percentage reported as activity, at one concentration (the size of the read-out at that concentration, not a potency): 2%
For compound 3 the middle estimate is 47 percentage points below the measured one; the whole stated range lies below it.
By their numbers in this assay, from the lowest: compound 2; then compound 1; then compound 3.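

For the compounds shown here, the change to 3,4-difluorophenyl on the carbonyl carbon gives a number 66 percentage points higher from compound 2 to compound 3 (beyond the scatter) in one comparison and a number 26 percentage points higher from compound 1 to compound 3 (beyond the scatter) in the other, so this position carries a wider spread than the single earlier step showed. Compound 3 at 2% is the only one of the three on the positive side of zero, and all three groups here now stand apart, with 4-methoxyphenyl lowest and 3,4-difluorophenyl highest.

Open, on these data alone, is where a carboxylic acid or a dimethylamino group on the phenyl ring would fall in this order, and whether the order holds with changes elsewhere on the shared core. Nothing at hand gives a reason for the order.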